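From 4-bromophenyl to 3,4-dimethoxyphenyl at a growth-inhibition limit

A few compounds are considered here, and "the series" means these few. Any claim that something is new, unique, unknown or untested is made for them only; others in the source may bear on it.

Values in a functional assay on HeLa cells (Homo sapiens) for inhibition, read by MTT assay, with a stated time of 48 h; on this read-out lower numbers stand for stronger inhibition of growth and higher numbers for weaker inhibition of growth:
- compound 1 `Cn1cc(C2CC(c3ccccc3)=NN2C(=O)c2cccnc2Cl)c2ccccc21`: > 10000 nM, a limit
- compound 2 `Cn1cc(C2CC(c3ccc(F)cc3)=NN2C(=O)c2cccnc2)c2cc(Br)ccc21`: 630 nM
- compound 3 `Cn1cc(C2CC(c3ccc(Br)cc3)=NN2C(=O)c2cccnc2)c2cc(Br)ccc21`: > 10000 nM, a limit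

Compound 3 has no exact number, only the limit > 10000 nM. That places it at the limit of > 10000 nM in this assay, at which 2 of the 3 values shown sit.

The unmeasured compound 4 `COc1ccc(C2=NN(C(=O)c3cccnc3)C(c3cn(C)c4ccc(Br)cc34)C2)cc1OC` differs from compound 3 in one place: 3,4-dimethoxyphenyl in place of 4-bromophenyl on a carbon with a double bond to nitrogen. In words, 3,4-dimethoxyphenyl stands in place of 4-bromophenyl on a carbon with a double bond to nitrogen.

Within the data shown here, one measured step concerns this same aromatic ring: an at least 15-fold higher number from compound 2 to compound 3 (1.20 log units; beyond the scatter). This large step shows that a change on this ring can strongly shift the result. It involves different groups, however, and ends at a limit, so it fixes no exact size for the new change.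

Compound 2 reaches a real number, 630 nM, so a moderate move to a lower number is expected. Another limit remains quite possible. The expected change is an at least 2.0-fold lower number from compound 3 to compound 4 (0.30 log units; that floor lies within the scatter). For compound 4 the estimated value is 5000 nM, with an expected range from 1000 nM to 20000 nM.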

Compound 4, concentration for 50% growth inhibition: 2090 nM
Beside the measured number, compound 4's estimate is 2.4-fold (0.38 log units) above it; the measured number falls inside the stated range.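

In this assay, this position on the carbon with a double bond to nitrogen tolerates more than 4-fluorophenyl: the change to 3,4-dimethoxyphenyl gives an at least 4.7-fold lower number from compound 3 to compound 4 (0.67 log units; beyond the scatter), and compound 4 reaches a real number where compound 3 does not. Even so, 3,4-dimethoxyphenyl does not fully match 4-fluorophenyl, as the comparison shows a 3.3-fold higher number from compound 2 to compound 4 (0.52 log units; beyond the scatter). The step from compound 3 starts from a limit rather than a number, so its true size remains unknown: the limit of > 10000 nM in this assay, at which 2 of the 4 values shown sit.

The compounds shown leave open whether both methoxy groups are needed, or whether 4-methoxyphenyl alone would give a similar result. They also leave open how a ring carrying an amine or a carboxylic acid would behave at this position.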